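The source may hold more compounds than are shown below. What is called first, only, known or untested is meant among the compounds shown, and "the series" means these compounds.

Measured compounds:
compound 1, `C=C1C(=O)[C@]23C[C@@]1(O)CC[C@H]2c1ccc(O)c(C)c1[C@@H]3Cn1cc(-c2ccc(C(F)(F)F)cc2)nn1` — 1440 nM
compound 2, `Cc1ccc(-c2cn(C[C@H]3c4c(ccc(OS(=O)(=O)c5ccc(C)cc5)c4C)[C@@H]4CC[C@@]5(C)C[C@]43CC5=O)nn2)cc1` — > 20000 nM

Compound 1 carries the only numerical result in a functional assay on SMMC-7721 cells (Homo sapiens) for cytotoxicity, read by MTT assay, with a stated time of 4 days; a higher number here means a weaker inhibitor, a lower number a stronger inhibitor. For compound 2 the result in this assay is a limit, (the limit of > 20000 nM in this assay, at which 1 of the 2 values shown sits). Compound 3, `C=C1C(=O)[C@]23C[C@@]1(O)CC[C@H]2c1ccc(O)c(C)c1[C@@H]3Cn1cc(-c2ccc(F)cc2)nn1`, has not yet been measured. It differs from compound 1 by fluoro in place of trifluoromethyl on an aromatic carbon. Going by the values given here, no measured pair of compounds shows this change, and its size is therefore unknown from the data at hand. A small loss is expected, a step of a 1.7-fold higher number from compound 1 to compound 3 (0.24 log units; within the scatter) that may not exceed the usual scatter. Compound 3 is estimated at 2500 nM, with a range of 900 nM to 7000 nM.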

Compound 3, half-maximal inhibitory concentration: 850 nM
Estimate against measurement, compound 3: 2.9-fold (0.47 log units) above; measured number below the stated range.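

Going from trifluoromethyl to fluoro on this aromatic carbon gives a 1.7-fold lower number from compound 1 to compound 3 (0.23 log units; within the scatter) in this assay. Going by these compounds alone, the 4-(trifluoromethyl)phenyl and 4-fluorophenyl groups are therefore not told apart at this place, which the earlier compounds could not show, as no measured pair differed here alone. Nothing measured gives a cause for this step. From the compounds shown here alone, whether an amine, a carboxylic acid or a methoxy group on this carbon would stay within the scatter of these two values remains open. So does the result for a plain phenyl carrying no group at this place.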